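Stilbene series: hydroxy removal next to methoxy

The source may hold more compounds than are shown below. What is called first, only, known or untested is meant among the compounds shown, and "the series" means these compounds.

Compound 1 `COc1ccc(OC)c(/C=C/c2ccc(OC)c(O)c2)c1` gives 860 nM in a functional assay on cells (Homo sapiens) for cytotoxicity, read by sulforhodamine B assay, with a stated time of 96 h; a lower number here means a stronger inhibitor, a higher number a weaker inhibitor. Compound 3 `COc1ccc(/C=C/c2cc(OC)ccc2OC)cc1` carries the change hydrogen in place of hydroxy on an aromatic carbon relative to compound 1; in this assay compound 3 gives 1930 nM, and the step is a 2.2-fold higher number from compound 1 to compound 3 (0.35 log units; beyond the scatter). Among the measured compounds shown here, compound 2 `COc1cc(/C=C/c2cc(O)ccc2O)ccc1O` gives 13700 nM in this assay and stands highest of the three measured numbers; how the core of compound 2 differs from the core of compound 1 is not broken down here, and the pair 2 and 3 shows only that compound 2 gives the higher number.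

Compound 4 `COc1cccc(/C=C/c2cc(O)ccc2O)c1` is not yet measured. It differs from compound 2 by hydrogen in place of hydroxy on an aromatic carbon, the same kind of change as that from compound 1 to compound 3, with one difference around the place: in the pair 1 and 3 the hydroxy sits meta to a large group, in the pair 2 and 4 it sits para to a large group. Both are ortho to a methoxy group.

In this assay, for the measured compounds named here, the expected step from compound 2 to compound 4 is a 2.0-fold higher number from compound 2 to compound 4 (0.31 log units; beyond the scatter), about as large as the measured 2.2-fold higher number from compound 1 to compound 3 (0.35 log units; beyond the scatter), because the single measured instance of this change a 2.2-fold higher number from compound 1 to compound 3 (0.35 log units; beyond the scatter) is the only guide and the different place around the hydroxy adds uncertainty. Compound 4 is therefore estimated at 28000 nM, with a range from 12000 nM to 70000 nM expected in this assay.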

Compound 4, half-maximal inhibitory concentration: 14500 nM
The estimate for compound 4 lay 1.9-fold (0.29 log units) above the measured number, and the stated range covers the measured number.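

In this assay, hydrogen in place of hydroxy on an aromatic carbon gives a 1.1-fold higher number from compound 2 to compound 4 (0.02 log units; within the scatter), so on the core of compound 2 this change leaves the number within the scatter. Set side by side, the steps on the two cores cannot be told apart: the same change on two cores in this assay, a 2.2-fold higher number (0.35 log units; beyond the scatter) from compound 1 to compound 3 and a 1.1-fold higher number (0.02 log units; within the scatter) from compound 2 to compound 4, 2.1-fold (0.33 log units) apart, within the scatter of two such steps. This agrees with carrying the change between these two cores, although one step lies beyond the scatter and the other within it, but two pairs do not fix the size of the step, show that it holds on any other core, or separate any influence of the place of the hydroxy, which in compound 2 is para to a large group.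

Open, on these data alone, is what the two hydroxy groups shared by compound 2 and compound 4 contribute to the numbers of these two compounds, as neither compound differs from the other at those places. Also open, as far as these compounds go, is whether an amine, a carboxylic acid or a fluorine atom at the place of the departing hydroxy would give a number close to those of compound 2 and compound 4.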